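A few compounds are considered here, and "the series" means these few. Any claim that something is new, unique, unknown or untested is made for them only; others in the source may bear on it.

Of the compounds shown here, two have so far been measured in a functional assay on MKN-45 cells (Homo sapiens) for cytotoxicity, read by MTT assay, with a stated time of 48 h; a higher number here means a weaker inhibitor, a lower number a stronger inhibitor. Compound 1 `CCCc1nnc(SCc2ccccc2Cl)n1N1C(=O)c2ccccc2C1=O` gives only a limit there, > 200000 nM. Compound 2 `C=CCSc1nnc(-c2cc(OC)c(OC)c(OC)c2)n1N1C(=O)c2ccccc2C1=O` also gives only a limit, > 200000 nM. Both results thus sit at the limit of > 200000 nM in this assay, at which 2 of the 2 values shown sit, and compound 2 stands at the same limit as compound 1 on the numbers shown. Compound 3 `COc1cc(-c2nnc(SCc3ccccc3Cl)n2N2C(=O)c3ccccc3C2=O)cc(OC)c1OC` differs from compound 2 by 2-chlorophenyl in place of vinyl on a saturated chain carbon bound to a sulfur. For the measured compounds named here, no step between measured compounds exists here, so the expected change from compound 2 to compound 3 is none beyond the scatter, a number no higher from compound 2 to compound 3 (the limit leaves the size open). Compound 3 is therefore expected at 200000 nM, in the range 100000 nM to 400000 nM, most likely again reported as a limit.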

Compound 3, half-maximal inhibitory concentration: > 200000 nM
Compound 3: no number, only a limit (the forecaster's own chance of this, stated with the estimate: 85%); the middle value sits exactly at the limit.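

Compound 3 gives only a limit, so the steps to it from compound 1 and compound 2 cannot be read: the limit of > 200000 nM in this assay, at which 3 of the 3 values shown sit.

The compounds shown leave open whether any of these changes on the shared core alters the result in this assay.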